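The source may hold more compounds than are shown below. What is called first, only, known or untested is meant among the compounds shown, and "the series" means these compounds.

Measured so far in a functional assay on KB cells (Homo sapiens) for inhibition, read by sulforhodamine B assay, with a stated time of 72 h; a lower number here means a stronger inhibitor of growth, a higher number a weaker inhibitor of growth:
Compound 1 `O=C(O)/C=C/c1ccncc1-c1ccc2cc[nH]c2c1` gives > 10000 nM, which is a limit of the assay.
Compound 2 `O=C(O)CCc1ccncc1-c1ccc2ccccc2c1` gives > 10000 nM, also a limit.
Compound 3 `O=C(CCc1ccncc1-c1ccc2ccccc2c1)N1CCOCC1` gives > 10000 nM, again a limit.

Compound 2 therefore has no number of its own, only a limit, and the same holds for every other value shown, as the limit of > 10000 nM in this assay, at which 3 of the 3 values shown sit, records. Going by the values given here, the single measured step, a step that the two limits leave unreadable from compound 2 to compound 3, cannot be read for size or direction. Compound 4 `CCOC(=O)/C=C/c1ccncc1-c1ccc2ccccc2c1` differs from compound 2 by 2-(ethoxycarbonyl)ethenyl in place of 2-carboxyethyl on an aromatic carbon. Among the compounds with values here, no measured step bears on this kind of change, so there is no ground to expect a move beyond the scatter in this assay in either direction. Compound 4 is thus expected near 15000 nM, within 3000 nM to 60000 nM, most probably again reported only as a limit. The expected step that the limit leaves unreadable from compound 2 to compound 4 is accordingly close to none.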

Compound 4, concentration for 50% growth inhibition: > 10000 nM
Compound 4 gave a limit, no number (the forecaster's own chance of this, stated with the estimate: 75%); the middle value lies beyond the limit too.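

Compound 2 and compound 4 both stop at a limit, so the step between them cannot be read for size or direction: the limit of > 10000 nM in this assay, at which 4 of the 4 values shown sit.

The compounds shown leave open which change, if any, would give a real number in this assay.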